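This account rests on a few compounds, and the source may have more. Where it says the series, first, only, none or still open, it means among the compounds named here.

Measured compounds, with values in a functional assay (aorta) with Rattus norvegicus as the target; on this read-out lower numbers stand for lower potency and higher numbers for higher potency (the scale is a negative logarithm):
compound 1 `COc1ccc2c(c1)C(n1ccccc1=O)=CC(C)(C)O2` — 6.55
compound 2 `CC1(C)C=C(n2ccccc2=O)c2cc(C(=O)c3ccccc3)ccc2O1` — 6.61

Compound 1 stands at the lower of the two numbers, but its nearest neighbour, compound 2, sits at a distance that is within the scatter, so the two cannot be ordered: a number 0.06 log units higher from compound 1 to compound 2 (within the scatter).

The unmeasured compound is compound 3 `CC1(C)C=C(n2ccccc2=O)c2cc(OS(=O)(=O)F)ccc2O1`. It differs from compound 1 in one place: fluorosulfonyl in place of methyl on an oxygen on an aromatic ring. Put one bond further out, this is methoxy giving way to (fluorosulfonyl)oxy, with the oxygen on the aromatic ring kept.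

Within the data shown here, only one measured step bears on this position. It swaps the methoxy of compound 1 for benzoyl and moves the number by a number 0.06 log units higher from compound 1 to compound 2 (within the scatter), a change within the scatter. Among the measured compounds shown here, that step replaces the whole methoxy; the change to compound 3 instead keeps the ring oxygen and exchanges only what sits on it, so it is not the same transformation, and no step of this exact kind is available.

For the measured compounds named here, with the one step at this place showing no movement beyond the scatter, the expectation for compound 3 is a number close to that of compound 1, with a wide range to cover the untested change: a number 0.05 log units lower from compound 1 to compound 3 (within the scatter). Compound 3 is therefore estimated at 6.5, between 5.9 and 7.1.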

Compound 3, logarithm of the reciprocal of the active concentration, log(1/C): 7.95
For compound 3 the middle estimate is 1.45 log units below the measured one; measured number outside the range, above it.
By their numbers in this assay, from the lowest: compounds 1 and 2 (each within the scatter of the next); then compound 3.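

In this assay, the group on the oxygen on the aromatic ring proves able to move the number: fluorosulfonyl in place of methyl gives a number 1.40 log units higher from compound 1 to compound 3 (beyond the scatter) and so marks this oxygen as a place where the exchange of a single group counts. (Fluorosulfonyl)oxy in place of benzoyl on the aromatic carbon gives a number 1.34 log units higher from compound 2 to compound 3 (beyond the scatter) and thereby separates compound 3 from both earlier compounds, which could not be ordered. The lack of movement beyond the scatter between methoxy and benzoyl therefore does not extend to every group at this place, and compound 3 is the highest of the three in this series. Nothing shown here bears on the origin of this rise, so it stands as an observation without an explanation.

From the compounds shown here alone, it remains open whether the rise is particular to fluorosulfonyl or would also appear with methanesulfonyl, acetyl or a free hydroxyl at the same oxygen. Also open, going by these compounds, is how a nitrile, an amine or a carboxylic acid would read on the same aromatic carbon, so the limits of this position in this assay are still undefined.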